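This account rests on a few compounds, and the source may have more. Where it says the series, first, only, none or still open, it means among the compounds named here.

The compounds share one core. Compound 1 `C=CC(=O)N1C(CC(=O)OCCCC)c2cccc(C)c2S1(=O)=O` carries it with an acryloyl group on the nitrogen, and in an assay on HEK-Blue hNOD1 cells for antagonist activity at Nucleotide-binding oligomerization domain-containing protein 1 (Homo sapiens), read by reporter gene assay, with stated times of 3 h and 20 h (a higher number here means a weaker inhibitor, a lower number a stronger inhibitor), compound 1 gives "not determined" (no result reported), so no result was reported for it. Going by the values given here, compound 2 `CCCCOC(=O)CC1c2cccc(C)c2S(=O)(=O)N1C(=O)c1ccc(C(F)(F)F)cc1` gives 1310 nM in this assay, the lowest of the two numbers known. Among the compounds with values here, its nearest neighbour, compound 3 `CCCCOC(=O)CC1c2ccc(Cl)c(C)c2S(=O)(=O)N1C(=O)c1ccc(C(F)(F)F)cc1`, gives 8370 nM in this assay, and the step of a 6.4-fold higher number from compound 2 to compound 3 (0.81 log units; beyond the scatter) is the only measured step in the set. Compound 4 `COC(=O)CC1c2cccc(C)c2S(=O)(=O)N1C(=O)c1ccc(C(F)(F)F)cc1` differs from compound 2 by hydrogen in place of propyl on a saturated chain carbon bound to an oxygen next to a carbonyl group, a change on the butoxycarbonyl chain rather than on the aromatic ring. Within the data shown here, no measured step touches that chain: the single known step, from compound 2 to compound 3, alters the aromatic ring and gives no guide to the size or direction of a change in the chain. With nothing to draw on, the expectation is for a change that stays within the scatter, with a range wide enough to cover either direction. Compound 4 is therefore expected to give about 1800 nM in this assay, within a range from 600 nM to 6000 nM. The step this implies is estimated as a 1.4-fold higher number from compound 2 to compound 4 (0.14 log units; within the scatter).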

Compound 4, half-maximal inhibitory concentration: 2980 nM
The estimate for compound 4 lay 1.7-fold (0.22 log units) below the measured number; the measured number falls inside the stated range.
By their numbers in this assay, from the lowest: compound 2; then compound 4; then compound 3.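

Changing butoxycarbonyl to methoxycarbonyl gives, in this assay, a 2.3-fold higher number from compound 2 to compound 4 (0.36 log units; beyond the scatter). Going by these compounds alone, this shows that the position on a saturated chain carbon bound to an oxygen next to a carbonyl group does register in the read-out and that, between these two compounds, the butoxycarbonyl chain goes with the lower number, something the earlier compounds could not show, as their only measured step lay on the aromatic ring. The chain step is also the smaller of the two steps known from compound 2, the other being a 6.4-fold higher number from compound 2 to compound 3 (0.81 log units; beyond the scatter), though both changes lead to a higher number, and no measurement on hand offers an explanation for the effect of the chain.

With only the butoxycarbonyl and methoxycarbonyl chains in hand, the compounds shown leave open whether the number follows chain length in a steady way, and how an ethyl ester, a longer or branched chain, a carboxylic acid or an amide would read at this position. As far as these compounds go, it also remains open whether the methoxycarbonyl chain would produce a similar step when combined with the chloro group of compound 3.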